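A few compounds are considered here, and "the series" means these few. Any claim that something is new, unique, unknown or untested is made for them only; others in the source may bear on it.

Compound 1 `CCCN(CCC)c1c(Cl)cc(Cl)c2nc(Nc3c(C)cc(Cl)cc3OC)n(C)c12`, 170 nM.
Compound 2 `CCN(CC)c1ccc(-c2ccccc2)c2nc(Nc3c(C)cc(Cl)cc3OC)n(C)c12`, > 10000 nM.

Among the measured compounds shown here, in an assay on CHO cells for displacement of a labelled ligand from corticotropin-releasing factor receptor 1 (Homo sapiens), read by scintillation counting, with a stated time of 1.5 h (a lower number here means a stronger inhibitor, a higher number a weaker inhibitor), compound 1 gives 170 nM, the only plain number among the two. Compound 2 reaches only the assay limit of > 10000 nM, which is a limit and not a number; the limit of > 10000 nM in this assay, at which 1 of the 2 values shown sits, describes it. Compound 3 `CCCN(CCC)c1c(Cl)ccc2nc(Nc3c(C)cc(Cl)cc3OC)n(C)c12` is not yet measured. It differs from compound 1 by hydrogen in place of chloro on an aromatic carbon. For the measured compounds named here, no measured pair shows this step, so compound 1 alone anchors the expectation, and a modest weakening, near the edge of the scatter, is expected. Compound 3 is estimated at 400 nM, with a range from 120 nM to 1500 nM. The expected step of a 2.4-fold higher number from compound 1 to compound 3 (0.37 log units; beyond the scatter) is a small loss.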

Compound 3, half-maximal inhibitory concentration: > 10000 nM
Compound 3 gave a limit, no number; the forecaster's own chance of this, stated with the estimate: 5%; middle value at least 25-fold (1.39 log units) away from the limit.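

In this assay, among the compounds shown here, the chloro para to the dipropylamino group proves to matter: replacing it with hydrogen gives an at least 58-fold higher number from compound 1 to compound 3 (1.76 log units; beyond the scatter), a large loss that the earlier compounds, with no pair differing in one place, could not show. The reading for compound 3 is a limit and not a number, and the full size of the step stays unknown: the limit of > 10000 nM in this assay, at which 2 of the 3 values shown sit.

From the compounds shown here alone, whether fluoro, bromo, methyl or methoxy at this carbon would keep the inhibition seen with chloro stays open. So does the contribution of the other chloro group on this ring.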